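The compounds below may be only part of what the source reports. "The series", "measured", "known", "first", "only" and "open" are said of these compounds alone.

Compound 2 `Cc1ccc2[nH]c(=O)c(CN(Cc3ccc(F)cc3)Cc3ccc(C(C)(C)C)cc3)cc2c1` stands at a limit in a toxicity assay on MDCK cells (Canis lupus familiaris) for cytotoxicity, read by crystal violet staining, with a stated time of 48 h; on this read-out lower numbers stand for higher toxicity in this test and higher numbers for lower toxicity in this test; in this assay compound 2 gives > 27000 nM. Compound 1 `Cc1ccc2[nH]c(=O)c(CN(Cc3ccccc3)Cc3ccc(C(C)(C)C)cc3)cc2c1` likewise stands at a limit, giving > 5000 nM in this assay. Compound 3 `CCCc1ccc2[nH]c(=O)c(CN(Cc3ccc(F)cc3)Cc3ccc(C(C)(C)C)cc3)cc2c1` gives a number in this assay, 8400 nM. The step from compound 1 to compound 2, fluoro in place of hydrogen on an aromatic carbon, reads as a step that the two limits leave unreadable from compound 1 to compound 2, since the limit of > 27000 nM in this assay, at which 1 of the 3 values shown sits, and the limit of > 5000 nM in this assay, at which 1 of the 3 values shown sits, are both limits. The step from compound 2 to compound 3, ethyl in place of hydrogen on a saturated chain carbon bound to an aromatic carbon, is an at least 3.2-fold lower number from compound 2 to compound 3 (0.50 log units; beyond the scatter).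

Compound 4 `Cc1ccc2[nH]c(=O)c(CN(CCCO)Cc3ccc(C(C)(C)C)cc3)cc2c1` differs from compound 2 by 2-hydroxyethyl in place of 4-fluorophenyl on a saturated chain carbon bound to an amine nitrogen. Going by the values given here, neither measured step touches the substituent on the amine nitrogen; the one readable step sits on the shared core. Among the compounds with values here, no measured step therefore bears directly on this change, and no shift beyond the scatter in this assay is expected from it. Compound 4 is estimated at 20000 nM in this assay, in the range 5000 nM to 80000 nM. The expected step is an at least 1.3-fold lower number from compound 2 to compound 4 (0.13 log units; that floor lies within the scatter).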

Compound 4, half-maximal cytotoxic concentration: > 10000 nM
Compound 4: no number, only a limit; the forecaster's own chance of this, stated with the estimate: 50%; the middle value lies beyond the limit too.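

Compound 4, like compound 1 and compound 2, stands at a limit in this assay, and the steps from compound 1 and compound 2 to compound 4 cannot be read. The compounds shown leave open whether 3-hydroxypropyl in place of 4-fluorobenzyl shifts the number in this assay at all, and in which direction.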